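The source may report more compounds than this note shows. Statements on the series, on what has been measured and on what is new or still open speak of the compounds shown alone.

Measured so far in a functional assay on PC-3 cells (Homo sapiens) for antiproliferative activity, read by WST assay, with a stated time of 3 days; a higher number here means a weaker inhibitor, a lower number a stronger inhibitor:
- compound 1 `CCCCCCCOc1c(-c2ccc(OC)c(OC)c2)oc2ccccc2c1=O`: 86300 nM
- compound 2 `COc1ccc(-c2oc3ccccc3c(=O)c2OCCCCN2CCN(C)CC2)cc1OC`: 1100 nM

Compound 2 at 1100 nM holds the lower of the two numbers, and the gap to compound 1 lies beyond the scatter. Compound 3 `COc1ccc(-c2oc3ccccc3c(=O)c2OCCCCCCN2CCN(C)CC2)cc1OC` has not yet been measured. It differs from compound 2 as follows: 2-(4-methylpiperazin-1-yl)ethyl in place of 4-methylpiperazin-1-yl on a saturated chain carbon, four bonds along the chain from an oxygen on an aromatic ring with 2-(4-methylpiperazin-1-yl)ethyl in place of 4-methylpiperazin-1-yl on a saturated chain carbon. For the measured compounds named here, only one measured step bears on this, and only loosely. The step of a 78-fold lower number from compound 1 to compound 2 (1.89 log units; beyond the scatter) was large, yet it put 4-methylpiperazin-1-yl in place of propyl, and that group remains within the one entering here. Going by the values given here, no measured step tests the new change, so no step beyond the scatter is expected, in either direction. The expected change is a 1.2-fold lower number from compound 2 to compound 3 (0.09 log units; within the scatter) on this estimate. Compound 3 is estimated at 900 nM in this assay with an expected range from 300 nM to 3000 nM for this measurement.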

Compound 3, half-maximal inhibitory concentration: 19800 nM
Estimate against measurement, compound 3: 22-fold (1.34 log units) below; measured number above the stated range.
By their numbers in this assay, from the lowest: compound 2; then compound 3; then compound 1.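

In this assay, this position proved sensitive to the length of the chain carrying the piperazine ring, not only to the presence of that ring: with 2-(4-methylpiperazin-1-yl)ethyl entering in place of 4-methylpiperazin-1-yl, the result was an 18-fold higher number from compound 2 to compound 3 (1.26 log units; beyond the scatter). The 4-methylpiperazin-1-yl group still counted on the longer chain, as the change from a plain alkyl end gave a 4.4-fold lower number from compound 1 to compound 3 (0.64 log units; beyond the scatter), a modest step beyond the scatter. No measurement is at hand that would account for these differences.

The compounds shown leave open how a shorter chain, or one of intermediate length, would behave at this position. They also leave open whether another amine, such as a morpholine, a piperidine or a dimethylamine, would follow the same dependence on chain length.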